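A Bicyclic Amide in Place of a Pyridine Amide

This account rests on a few compounds, and the source may have more. Where it says the series, first, only, none or still open, it means among the compounds named here.

Compound 1 `COc1ccccc1C(=O)Nc1cccc(NC(=O)c2cc(Cl)cc(Cl)c2)c1`: in an in vitro functional assay on HEK293-A cells for antagonist activity at metabotropic glutamate receptor 5 (Rattus norvegicus), read by calcium flux (on this read-out lower numbers stand for stronger inhibition and higher numbers for weaker inhibition), compound 1 gives > 30000 nM, which is a limit of the assay rather than a number.
Compound 2 `COc1ccccc1C(=O)Nc1cccc(NC(=O)c2ccc(F)cc2)c1`: in this assay compound 2 gives > 30000 nM, also a limit.
Compound 3 `O=C(Nc1cccnc1)c1cccc(N2C(=O)c3ccccc3C2=O)c1`: in this assay compound 3 gives > 30000 nM, again a limit.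

Going by these compounds, compound 3 therefore stands at the limit of > 30000 nM in this assay, at which 3 of the 3 values shown sit, so its true potency is unknown beyond that point. Compound 4 `O=C(NC1CC2CCC1C2)c1cccc(N2C(=O)c3ccccc3C2=O)c1` differs from it by a group of 7 heavy atoms (7 carbon; 2 five-membered non-aromatic rings of carbon only) in place of a group of 6 heavy atoms (5 carbon, 1 nitrogen; one six-membered aromatic ring with 1 hetero atom), on an amide-type nitrogen. For the measured compounds named here, the only measured step, a step that the two limits leave unreadable from compound 1 to compound 2, sits between two limits and gives no readable size, and it concerns a different part of the molecule. Going by the values given here, no measured step bears directly on the change to compound 4. Compound 4 is expected to stay at or near the limit, with an estimated step that the limit leaves unreadable from compound 3 to compound 4. The estimate for compound 4 is 40000 nM, ranging from 8000 nM to 200000 nM.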

Compound 4, half-maximal inhibitory concentration: > 30000 nM
Compound 4 gave a limit, no number; the forecaster's own chance of this, stated with the estimate: 80%; the middle value is on the limit's open side.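

Compound 3 and compound 4 both give a limit rather than a number, so no step between them can be read: the limit of > 30000 nM in this assay, at which 4 of the 4 values shown sit.

The compounds shown leave open how strongly any of them truly inhibits the receptor, and which change would bring a readable value.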